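Aryl Exchange on the Shared Core: Expectation for Compound 3

This account rests on a few compounds, and the source may have more. Where it says the series, first, only, none or still open, it means among the compounds named here.

Compound 1 `CCOC(=O)c1cnc(-c2cccs2)nc1NN1C(=O)C=C(C)C1=O` gives 20 nM in a functional assay on Jurkat cells for inhibition of nuclear factor NF-kappa-B complex (Homo sapiens); on this read-out higher numbers stand for weaker inhibition and lower numbers for stronger inhibition.
Compound 2 `CCOC(=O)c1cnc(-c2ccc(F)cc2)nc1NN1C(=O)C=C(C)C1=O` gives 700 nM in this assay.

Among the compounds with values here, compound 2 stands at the higher of the two numbers; the only measured step, a 35-fold higher number from compound 1 to compound 2 (1.54 log units; beyond the scatter), is large and replaces a thiophen-2-yl with a phenyl ring. Compound 3 `CCOC(=O)c1cnc(-c2cccc(Br)c2)nc1NN1C(=O)C=C(C)C1=O` differs from compound 2 by 3-bromophenyl in place of 4-fluorophenyl on an aromatic carbon. Within the data shown here, no measured step exchanges one halogen-bearing phenyl for another, so that step bears only loosely on this change. Compound 3 is therefore expected to stay close to compound 2, with an estimated step of a 1.2-fold lower number from compound 2 to compound 3 (0.07 log units; within the scatter) in this assay, and an estimated value of 600 nM (range 120 nM to 3000 nM).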

Compound 3, half-maximal inhibitory concentration: 700 nM
For compound 3 the middle estimate is 1.2-fold (0.07 log units) below the measured one, within the range that was stated.
By their numbers in this assay, from the lowest: compound 1; then compounds 2 and 3 (each within the scatter of the next).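

In this assay, the exchange of one halogen-bearing phenyl for another gives no change at the digits printed from compound 2 to compound 3 (within the scatter), so 3-bromophenyl and 4-fluorophenyl are not told apart at this aromatic carbon, although both the halogen and its ring position differ. Set against thiophen-2-yl, 3-bromophenyl gives a 35-fold higher number from compound 1 to compound 3 (1.54 log units; beyond the scatter), so a second phenyl ring shows the same large gap as the 4-fluorophenyl. Nothing available explains why thiophen-2-yl stands apart from both phenyl rings. From the compounds shown here alone, whether a furan-2-yl or pyridin-3-yl group would fall with compound 1 or with compounds 2 and 3 remains open.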